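Exchanging one aromatic group in a growth inhibitor

This account rests on a few compounds, and the source may have more. Where it says the series, first, only, none or still open, it means among the compounds named here.

Measured in a functional assay on HCC827 cells (Homo sapiens) for inhibition, read by fluorescence, with a stated time of 72 h; on this read-out higher numbers stand for weaker inhibition of growth and lower numbers for stronger inhibition of growth:
Compound 1 `COc1ccc(Nc2nc(N[C@H]3CC[C@H](N)CC3)nc3c2ncn3CCC(C)C)c(OC)c1`: 32900 nM
Compound 2 `COc1ccc(Cn2cnc3c(Nc4cccc(Cl)c4)nc(N[C@H]4CC[C@H](N)CC4)nc32)cc1`: 18700 nM
Compound 3 `CCCCCCn1cnc2c(Nc3cc(OC)cc(OC)c3)nc(N[C@H]3CC[C@H](N)CC3)nc21`: 9100 nM

Compound 1 and compound 2 sit together at the high end, within the scatter of each other, and compound 3 is clearly lower. Compound 4 `CC(C)CCn1cnc2c(Nc3cccc(Cl)c3)nc(N[C@H]3CC[C@H](N)CC3)nc21` has not been measured yet. It keeps the core of compound 1 and changes one group: 3-chlorophenyl in place of 2,4-dimethoxyphenyl on a nitrogen on an aromatic ring. Compound 2 carries the same 3-chlorophenyl and gives 18700 nM, but it also differs elsewhere, so it offers only a rough guide. Only a small move toward lower numbers in this assay is expected, and the estimated step of a 1.8-fold lower number from compound 1 to compound 4 (0.26 log units; within the scatter) stays within the scatter. Compound 4 is expected near 18000 nM, with an estimated range from 7000 nM to 40000 nM.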

Compound 4, concentration for 50% growth inhibition: 10300 nM
Estimate against measurement, compound 4: 1.7-fold (0.24 log units) above, within the range that was stated.
By their numbers in this assay, from the lowest: compounds 3, 4, 2 and 1 (each within the scatter of the next, the first and the last beyond it).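

In this assay, 3-chlorophenyl in place of 2,4-dimethoxyphenyl on a nitrogen on an aromatic ring gives a 3.2-fold lower number from compound 1 to compound 4 (0.50 log units; beyond the scatter), so the aromatic group at this position can matter. By contrast, isobutyl in place of 4-methoxyphenyl on a saturated chain carbon bound to an aromatic nitrogen gives a 1.8-fold lower number from compound 2 to compound 4 (0.26 log units; within the scatter), which shows no clear difference. Nothing measured here explains either step. As far as these compounds go, the first step removes both methoxy groups and adds the chlorine together, so the contribution of each remains unknown. From the compounds shown here alone, how a phenyl ring carrying an amine or a carboxylic acid would behave here also remains open.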